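A few compounds are considered here, and "the series" means these few. Any claim that something is new, unique, unknown or untested is made for them only; others in the source may bear on it.

Measured so far in a functional assay on NCI-H460 cells (Homo sapiens) for cytotoxicity, read by MTT assay, with a stated time of 68 h; a higher number here means a weaker inhibitor, a lower number a stronger inhibitor:
compound 1 `COc1cccc(-c2cccc(NC(=O)C(Cl)Cl)c2)c1` — 33800 nM
compound 2 `CC(C)c1ccc(-c2cc(NC(=O)C(Cl)Cl)cc(-c3ccc(C(C)C)cc3)c2)cc1` — 24800 nM
compound 3 `COc1ccccc1-c1cc(NC(=O)C(Cl)Cl)cc(-c2ccccc2OC)c1` — > 30000 nM

Compound 1 carries the higher of the two numbers in this assay, but its nearest neighbour is compound 2 and the gap between them lies within the scatter, so no order between the two can be read. For compound 3 this assay reports only a limit and not a number (the limit of > 30000 nM in this assay, at which 1 of the 3 values shown sits).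

Compound 4 `O=C(Nc1cccc(-c2ccccc2)c1)C(Cl)Cl` is not yet measured. It differs from compound 1 in one place: hydrogen in place of methoxy on an aromatic carbon. Going by the values given here, no step between measured compounds bears on this change, so the expectation rests on compound 1 alone. With only a methoxy leaving and a hydrogen entering, the step is expected to be small, in either direction, and not beyond the scatter. Compound 4 is therefore expected to give about 40000 nM in this assay, within 15000 nM to 90000 nM. The step from a 1.2-fold higher number from compound 1 to compound 4 (0.07 log units; within the scatter) that this estimate means is expected to be within the usual scatter.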

Compound 4, half-maximal inhibitory concentration: 20200 nM
Compound 4: middle estimate off by 2.0-fold (0.30 log units), on the high side, within the range that was stated.
By their numbers in this assay, from the lowest: compounds 4, 2 and 1 (each within the scatter of the next).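

Hydrogen in place of methoxy on an aromatic carbon, meta to a large group, is the first single change that can be read in this series, and in this assay it gives a step that stays inside the scatter (a 1.7-fold lower number from compound 1 to compound 4 (0.22 log units; within the scatter)). At this position, then, the methoxy can go without a change that can be told from repeat measurement, and compound 4 keeps the number in the same range with no group there at all. No measured property in hand bears on this step.

On these data alone, whether an amine or a carboxylic acid on this same aromatic carbon would give a step beyond the scatter remains open. So does the outcome of a longer chain there, such as ethoxy or propoxy, on the core of compound 1.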